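A Nitro Group Added to a Second Core

The source may hold more compounds than are shown below. What is called first, only, known or untested is meant among the compounds shown, and "the series" means these compounds.

The study covers four compounds. Compound 1 `S=C(N/N=C/c1ccc(Oc2ccccc2)cc1)Nc1ccc(Br)cc1` was measured in a physicochemical assay for lipophilicity, in phosphate buffer, measured as octanol-water partition, with a stated time of 24 h (a higher number here means a more lipophilic compound, a lower number a more polar compound), and gives 6.38. Compound 2 `O=[N+]([O-])c1ccc(Oc2ccc(/C=N/NC(=S)Nc3ccc(Br)cc3)cc2)cc1` differs from it in one place, (nitro in place of hydrogen on an aromatic carbon), and in this assay compound 2 gives 5.68; the step is a number 0.70 log units lower from compound 1 to compound 2 (beyond the scatter). Compound 3 `S=C(N/N=C/c1ccc(Oc2ccccc2)cc1)Nc1ccccc1` carries a different core, the difference being (hydrogen in place of bromo on an aromatic carbon); in this assay compound 3 gives 4.9, and the step is a number 1.48 log units lower from compound 1 to compound 3 (beyond the scatter). Of the three values, that of compound 3 is the lowest, with compound 2 nearest and compound 1 furthest. Compound 4 `O=[N+]([O-])c1ccc(Oc2ccc(/C=N/NC(=S)Nc3ccccc3)cc2)cc1` has not yet been measured. It differs from compound 3 by nitro in place of hydrogen on an aromatic carbon, the same change that separates compound 1 from compound 2, made here on the core of compound 3. Resting on a number 0.70 log units lower from compound 1 to compound 2 (beyond the scatter), the step expected for compound 4 is a number 0.70 log units lower from compound 3 to compound 4 (beyond the scatter). On that basis compound 4 is estimated at 4.2. The value of compound 4 is expected to fall between 3.7 and 4.7.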

Compound 4, partition coefficient: 4.95
For compound 4 the middle estimate is 0.75 log units below the measured one, outside the stated range (above it).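

In this assay the nitro change does not carry over from one core to the other: on the core of compound 1 it gives a step beyond the scatter (a number 0.70 log units lower from compound 1 to compound 2 (beyond the scatter)), while on the core of compound 3 the step stays within the scatter (a number 0.05 log units higher from compound 3 to compound 4 (within the scatter)). Read the other way round, the change from bromo to hydrogen also gives steps of different size, large without the nitro group (a number 1.48 log units lower from compound 1 to compound 3 (beyond the scatter)) and modest with it (a number 0.73 log units lower from compound 2 to compound 4 (beyond the scatter)). This shows that, among these four compounds, the size of the step depends on the core, but it rests on a single pair of cores, sets no rule for any other core, and nothing at hand explains the difference.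

The compounds shown leave open whether a similar dependence on the core appears when an amine or a carboxylic acid takes the place of the nitro group. They also leave open what chloro or methyl would give in the place of bromo.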